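Replacing amino with methyl in a stability series

A few compounds are considered here, and "the series" means these few. Any claim that something is new, unique, unknown or untested is made for them only; others in the source may bear on it.

Two close relatives have been measured in an ADME assay on microsomes from liver (Homo sapiens) for metabolic stability, read by LC-MS, with a stated time of 60 min, in the presence of a further agent that is not named here; on this read-out lower numbers stand for a less stable compound and higher numbers for a more stable compound. There compound 1 `COc1ccc(-c2ccc3ncc(-c4nnco4)c(NCCCn4ccnc4)c3c2)cc1` gives 112%, and compound 2 `Nc1ccc(-c2ccc3ncc(-c4nnco4)c(NCCCn4ccnc4)c3c2)cc1` gives 93.8%, the lower of the two numbers. The next structure, compound 3 `Cc1ccc(-c2ccc3ncc(-c4nnco4)c(NCCCn4ccnc4)c3c2)cc1`, keeps the rest of compound 2 and alters one group: methyl in place of amino on an aromatic carbon. Put simply, methyl takes the place of amino on an aromatic carbon, para to a large group. Going by the values given here, only one measured step bears on this change: a number 18.2 percentage points lower from compound 1 to compound 2 (beyond the scatter), a modest drop beyond the scatter, seen when amino replaced methoxy. Methyl is neither of those groups, and a single step shows no trend, so the direction is only a tentative expectation. The expected change is a small rise, a number 6.2 percentage points higher from compound 2 to compound 3 (within the scatter), which would not clearly exceed the scatter. The estimate for compound 3 is 100%, with an expected range from 82% to 116%.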

Compound 3, percent of the compound remaining: 93%
For compound 3 the middle estimate is 7 percentage points above the measured one, within the range that was stated.
By their numbers in this assay, from the lowest: compounds 3 and 2 (each within the scatter of the next); then compound 1.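

In this assay, methyl in place of amino gives a number 0.8 percentage points lower from compound 2 to compound 3 (within the scatter), so this assay does not separate the two groups at this position, even though amino has a hydrogen-bond donor and acceptor and methyl has neither. Methoxy now stands apart from both groups: replacing it with methyl gives a number 19 percentage points lower from compound 1 to compound 3 (beyond the scatter), alongside the step already seen with amino, a number 18.2 percentage points lower from compound 1 to compound 2 (beyond the scatter). Nothing available explains why methoxy differs from the other two groups.

The compounds shown leave open whether ethoxy or a fluorine atom on this carbon would stay close to methoxy or fall with amino and methyl. They also leave open whether the gap between methoxy and these two groups would persist if the shared core were changed elsewhere.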